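This account rests on a few compounds, and the source may have more. Where it says the series, first, only, none or still open, it means among the compounds named here.

Compound 1 `COc1cc(C)cc(-c2c(-c3ccnc(-c4ccc(C(C)=O)cc4)c3)cnn2CC#N)c1` stands lowest among the three measured compounds in a functional assay on HOP-92 cells (Homo sapiens) for cytotoxicity, read by sulforhodamine B assay, with a stated time of 48 h, tested at 1 uM (on this read-out higher numbers stand for a weaker effect at the one concentration tested and lower numbers for a stronger effect), where compound 1 gives -9%. Among the compounds with values here, compound 2 `COc1cc(C)cc(-c2nn(CC#N)cc2-c2ccnc(-c3ccc(N(C)C)cc3)c2)c1` in this assay gives 9%, and compound 3 `Cc1cc(O)cc(-c2nn(CC#N)cc2-c2ccnc(-c3ccc(N(C)C)cc3)c2)c1` gives 25%; the only measured step, a number 16 percentage points higher from compound 2 to compound 3 (beyond the scatter), concerns a different part of the molecule. Compound 4 `COc1cc(C)cc(-c2c(-c3ccnc(-c4ccc(N(C)C)cc4)c3)cnn2CC#N)c1` arises from compound 1 by the change (dimethylamino in place of acetyl on an aromatic carbon). Within the data shown here, no measured pair carries that exchange, so no step supports it directly; compound 2, which also carries the dimethylamino group although its connection to the shared core differs, is the nearest guide. Compound 4 is therefore expected to show a step of a number 14 percentage points higher from compound 1 to compound 4 (beyond the scatter), small and quite possibly within the scatter. The estimate for compound 4 is 5%, ranging from -15% to 25%.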

Compound 4, a percentage reported as activity, at one concentration (the size of the read-out at that concentration, not a potency): -20%
Compound 4: middle estimate off by 25 percentage points, on the high side; measured number below the stated range.
By their numbers in this assay, from the lowest: compound 4; then compound 1; then compound 2; then compound 3.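

Within the data shown here, the exchange of 4-acetylphenyl for 4-(dimethylamino)phenyl gives a number 11 percentage points lower from compound 1 to compound 4 (beyond the scatter) in this assay, the first measured step at this position and one toward the stronger effect. The position therefore takes either group with a stronger effect than any earlier compound showed, and the dimethylamino group ranks ahead of acetyl here. Nothing measured on these compounds accounts for the step.

From the compounds shown here alone, whether a primary amine or a carboxylic acid at this place would push the read-out further remains open. So does whether the same exchange gives a similar step on the differently connected core of compound 2.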